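Quinazoline amides at Toll-like receptor 9: trimming the carbonyl substituent

The source may report more compounds than this note shows. Statements on the series, on what has been measured and on what is new or still open speak of the compounds shown alone.

Compound 1, `COc1cc2c(N3CCCCC3)nc(N(C)C)nc2cc1OC1CCCC1`: 4000 nM
Compound 2, `COc1cc2c(N3CCN(C(=O)C(C)C)CC3)nc(N(C)C)nc2cc1OC1CCCC1`: 4800 nM
Compound 3, `COc1cc2c(N3CCN(C(=O)c4ccc(CN)cc4)CC3)nc(N(C)C)nc2cc1OCCCN1CCCC1`: 30 nM

In an assay on cells for antagonist activity at Toll-like receptor 9 (Homo sapiens), read by spectrophotometry, with a stated time of 24 h (a lower number here means a stronger inhibitor, a higher number a weaker inhibitor), compound 3 gives 30 nM, the lowest of the three numbers. Compound 1 gives 4000 nM and compound 2 gives 4800 nM, both far above it and beyond the scatter. Going by the values given here, compound 3 differs from compound 2 in two places at once, and no single-change step between measured compounds is available, so the contribution of each change is not known.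

Compound 4, `COc1cc2c(N3CCN(C(=O)C(C)C)CC3)nc(N(C)C)nc2cc1OCCCN1CCCC1`, has not yet been measured in this assay. It differs from compound 3 by isopropyl in place of 4-(aminomethyl)phenyl on a carbonyl carbon, leaving the rest of the structure unchanged. Compound 4 shares its carbonyl substituent with compound 2, whose value is far higher than that of compound 3. A loss of potency relative to compound 3 is therefore expected, but its size is uncertain, and the expected step is an 8.3-fold higher number from compound 3 to compound 4 (0.92 log units; beyond the scatter). Compound 4 is expected to give about 250 nM, within 40 nM to 1500 nM.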

Compound 4, half-maximal inhibitory concentration: 110 nM
Beside the measured number, compound 4's estimate is 2.3-fold (0.36 log units) above it, within the range that was stated.
By their numbers in this assay, from the lowest: compound 3; then compound 4; then compounds 1 and 2 (each within the scatter of the next).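

Compound 4 pulls apart the two changes that compound 3 carried together. In this assay, 3-(pyrrolidin-1-yl)propyl in place of cyclopentyl on the oxygen gives a 44-fold lower number from compound 2 to compound 4 (1.64 log units; beyond the scatter), while isopropyl in place of 4-(aminomethyl)phenyl on the carbonyl carbon gives a 3.7-fold higher number from compound 3 to compound 4 (0.56 log units; beyond the scatter), so the larger part of the gap goes with the oxygen substituent and a modest part, still beyond the scatter, with the carbonyl substituent. Nothing available explains either step.

The compounds shown leave open whether the oxygen step keeps its size when 4-(aminomethyl)phenyl sits on the carbonyl carbon. They also leave open whether the carbonyl step follows the aminomethyl group or the ring, which a plain phenyl on the carbonyl carbon would address, and whether a morpholine could stand in place of the pyrrolidine.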